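The source may hold more compounds than are shown below. What is called first, only, known or untested is meant among the compounds shown, and "the series" means these compounds.

Measured compounds:
- compound 1, `COc1ccc(-c2csc(N/N=C(\C)c3cc4ccccc4o3)n2)cc1`: 28900 nM
- compound 2, `C/C(=N\Nc1nc(-c2ccccc2)cs1)c1cc2ccccc2o1`: 16700 nM
- compound 3, `C/C(=N\Nc1nc(-c2cc3ccccc3o2)cs1)c1cc2ccccc2o1`: 34200 nM

In a functional assay on PC-3 cells (Homo sapiens) for antiproliferative activity (a lower number here means a stronger inhibitor, a higher number a weaker inhibitor), compound 2 gives the lowest of the three numbers. Its nearest neighbour is compound 1, with a 1.7-fold lower number from compound 1 to compound 2 (0.24 log units; within the scatter); its furthest is compound 3, with a 2.0-fold higher number from compound 2 to compound 3 (0.31 log units; beyond the scatter). Compound 4, `C/C(=N\Nc1nc(C)cs1)c1cc2ccccc2o1`, differs from compound 2 by methyl in place of phenyl on an aromatic carbon.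

Among the measured compounds shown here, two measured steps touch the same aromatic carbon. Removing the methoxy, from compound 1 to compound 2, gave a 1.7-fold lower number from compound 1 to compound 2 (0.24 log units; within the scatter). Exchanging the phenyl for 1-benzofuran-2-yl, from compound 2 to compound 3, gave a 2.0-fold higher number from compound 2 to compound 3 (0.31 log units; beyond the scatter). For the measured compounds named here, neither step replaced the ring with a chain, so there is no direct precedent for shrinking the group to a methyl. Going by the values given here, the numbers across the three compounds move little, and the one step that altered the group itself pushed the number higher. A modest rise, close to the edge of the scatter, is therefore expected, as a 1.6-fold higher number from compound 2 to compound 4 (0.19 log units; within the scatter). Compound 4 is accordingly estimated at 26000 nM in this assay, with a range from 8000 nM to 85000 nM.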

Compound 4, half-maximal inhibitory concentration: 8990 nM
Beside the measured number, compound 4's estimate is 2.9-fold (0.46 log units) above it; measured number inside the range.
By their numbers in this assay, from the lowest: compounds 4, 2, 1 and 3 (each within the scatter of the next, the first and the last beyond it).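

In this assay, among the compounds shown here, the earlier compounds carried only aromatic rings at this carbon, and compound 4 shows that a methyl, with no ring and 1 heavy atom, can stand there without loss against the phenyl: a 1.9-fold lower number from compound 2 to compound 4 (0.27 log units; within the scatter). Against the two other ring groups the change goes beyond the scatter, though modestly, with a 3.8-fold lower number from compound 3 to compound 4 (0.58 log units; beyond the scatter) and a 3.2-fold lower number from compound 1 to compound 4 (0.51 log units; beyond the scatter), so a ring at this carbon is not needed for the activity seen in this series. Nothing shown bears on why the methyl behaves in this way.

As far as these compounds go, whether a longer chain such as propyl, or a group such as an amine or a carboxylic acid, would be tolerated on this carbon remains open. So does the effect of plain hydrogen there.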